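This account rests on a few compounds, and the source may have more. Where it says the series, first, only, none or still open, it means among the compounds named here.

Three compounds sharing one core were tested in a functional assay on HEK293 cells for agonist activity at G-protein coupled receptor 52 (Homo sapiens), read by cAMP accumulation, with a stated time of 15 min; a lower number here means that less compound is needed, a higher number that more compound is needed for the effect. Compound 1 `O=C(NCCO)c1cccc2c1CCN2c1ccnc(Cc2cc(F)cc(C(F)(F)F)c2)n1` gives 373 nM. Compound 2 `O=C(NCCO)c1cccc2c1CCN2c1nncc(Cc2cc(F)cc(C(F)(F)F)c2)c1Cl` gives 565 nM. Compound 3 `O=C(NCCO)c1cccc2c1CCN2c1cc(Cc2ccc(C(F)(F)F)cc2)ncn1` gives 109 nM, the lowest of the three numbers; compound 1 stands nearest, beyond the scatter, and compound 2 furthest. Compound 4 `O=C(NCCO)c1cccc2c1CCN2c1cc(Cc2cccc(OC(F)(F)F)c2)ncn1` has not yet been measured in this assay. It differs from compound 3 in one place: 3-(trifluoromethoxy)phenyl in place of 4-(trifluoromethyl)phenyl on a saturated chain carbon bound to an aromatic carbon. Among the compounds with values here, no measured pair shows this change, so its size is uncertain. Because compound 1, with a differently substituted phenyl, gives 373 nM, a modest rise beyond the scatter is expected. Compound 4 is therefore expected to give 200 nM, within 50 nM to 800 nM. The expected step is a 1.8-fold higher number from compound 3 to compound 4 (0.26 log units; within the scatter).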

Compound 4, half-maximal effective concentration: 131 nM
Estimate against measurement, compound 4: 1.5-fold (0.18 log units) above; low and high end bracket the measured number.
By their numbers in this assay, from the lowest: compounds 3 and 4 (each within the scatter of the next); then compounds 1 and 2 (each within the scatter of the next).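

In this assay, the step is a 1.2-fold higher number from compound 3 to compound 4 (0.08 log units; within the scatter), so the two compounds cannot be told apart at this position. The chain-bound phenyl therefore accepts 3-(trifluoromethoxy)phenyl, which brings one oxygen and one hydrogen-bond acceptor, as readily as 4-(trifluoromethyl)phenyl. No measurement at hand accounts for this outcome. The change alters both the substituent and its numbered ring place at once, and the compounds shown do not separate the two. Going by these compounds, whether an amine or a carboxylic acid on this phenyl would be accepted also stays open.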